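The source may report more compounds than this note shows. Statements on the series, on what has been measured and on what is new or still open speak of the compounds shown alone.

Measured compounds in a functional assay on L1210 cells (Mus musculus) for inhibition, read by MTT assay, with a stated time of 72 h; a lower number here means a stronger inhibitor, a higher number a weaker inhibitor:
Compound 1, `COc1cc(NC(C)CCCNC(=O)NNC(=O)Nc2ccc(F)cc2)c2ncccc2c1`, gives 104000 nM.
Compound 2, `COc1cc(NC(C)CCCNC(=O)NNC(=O)Nc2ccc(Cl)cc2)c2ncccc2c1`, gives 58000 nM.
Compound 3, `COc1cc(NC(C)CCCNC(=O)Nc2ccc(C(F)(F)F)cc2)c2ncccc2c1`, gives 7400 nM.

Compound 1 stands with the highest of the three numbers. Its nearest neighbour is compound 2, a 1.8-fold lower number from compound 1 to compound 2 (0.25 log units; within the scatter), and its furthest is compound 3, a 14-fold lower number from compound 1 to compound 3 (1.15 log units; beyond the scatter). Compound 4, `COc1cc(NC(C)CCCNC(=O)NNC(=O)Nc2ccc(O)cc2)c2ncccc2c1`, has not yet been measured. It differs from compound 1 in one place: hydroxy in place of fluoro on an aromatic carbon.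

Among the measured compounds shown here, of the measured steps, only the one from compound 1 to compound 2 bears on this change, since it alone swaps the group on that aromatic carbon while leaving the rest of the molecule untouched, and it stayed within the scatter. The steps to compound 3, a 7.8-fold lower number from compound 2 to compound 3 (0.89 log units; beyond the scatter) among them, replace the whole ((4-fluorophenyl)carbamoyl)amino or ((4-chlorophenyl)carbamoyl)amino part and so speak to a different change. For the measured compounds named here, no measured compound carries a hydroxy group anywhere, so the direction of this step rests on little. He therefore expects no step beyond the scatter for compound 4, and estimates it at 120000 nM, in the range 40000 nM to 350000 nM, which would mean a 1.2-fold higher number from compound 1 to compound 4 (0.06 log units; within the scatter).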

Compound 4, half-maximal inhibitory concentration: 95000 nM
The estimate for compound 4 lay 1.3-fold (0.10 log units) above the measured number, and the stated range covers the measured number.
By their numbers in this assay, from the lowest: compound 3; then compounds 2, 4 and 1 (each within the scatter of the next).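

In this assay, hydroxy in place of fluoro gives a 1.1-fold lower number from compound 1 to compound 4 (0.04 log units; within the scatter), and hydroxy in place of chloro gives a 1.6-fold higher number from compound 2 to compound 4 (0.21 log units; within the scatter), so this aromatic carbon, para to a large group, has now carried three different groups with no step beyond the scatter, even though hydroxy alone among them is counted as a hydrogen-bond donor and acceptor. Among the compounds shown here, the one large change remains in the other part of the molecule, where ((4-hydroxyphenyl)carbamoyl)amino in place of 4-(trifluoromethyl)phenyl gives a 13-fold higher number from compound 3 to compound 4 (1.11 log units; beyond the scatter), so compound 4 falls with compound 1 and compound 2 rather than with compound 3. Nothing available explains why the swap at this carbon leaves the number within the scatter.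

As far as these compounds go, whether an amine, a carboxylic acid or a methoxy group on this same carbon would also stay within the scatter remains open. Also open, from the compounds shown here alone, is whether a hydroxy group in place of the trifluoromethyl of compound 3 would leave its number unchanged, or whether this position matters only in that setting.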